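The compounds below may be only part of what the source reports. "The series", "measured", "known", "first", "only" and "open" are said of these compounds alone.

Measured so far in a functional assay, read by spectrophotometry, with a stated time of 5 min; on this read-out lower numbers stand for stronger inhibition and higher numbers for weaker inhibition:
- compound 1 `COc1cc(/C=C/C(=O)C(=Cc2ccc(OC)c(OC)c2)C(=O)/C=C/c2ccc(O)c(OC)c2)ccc1O` at 71000000 nM
- compound 2 `CCOc1cc(C=C(C(=O)/C=C/c2ccc(O)c(OC)c2)C(=O)/C=C/c2ccc(O)c(OC)c2)ccc1O` at 123000000 nM

For the measured compounds named here, compound 2 stands level with compound 1, the only other measured compound, and the two values cannot be ranked. Compound 3 `COc1cc(/C=C/C(=O)C(=Cc2ccc(O)cc2)C(=O)/C=C/c2ccc(O)c(OC)c2)ccc1O` is compound 2 with one change, (hydrogen in place of ethoxy on an aromatic carbon), that is, 3-ethoxy-4-hydroxyphenyl to 4-hydroxyphenyl. Going by the values given here, the one measured step that bears on this is a 1.7-fold higher number from compound 1 to compound 2 (0.24 log units; within the scatter), and it produced the same 3-ethoxy-4-hydroxyphenyl group that now changes. Among the compounds with values here, no measured step removes an ethoxy group, so the support is thin. On this single small step, no shift beyond the scatter is expected in this assay, in either direction. The expected step is a 1.3-fold lower number from compound 2 to compound 3 (0.11 log units; within the scatter), an estimate only. Compound 3 is estimated at 95000000 nM, with an expected range of 35000000 nM to 260000000 nM.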

Compound 3, half-maximal inhibitory concentration: 48700000 nM
For compound 3 the middle estimate is 2.0-fold (0.29 log units) above the measured one; the measured number falls inside the stated range.
By their numbers in this assay, from the lowest: compounds 3, 1 and 2 (each within the scatter of the next, the first and the last beyond it).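

In this assay, for the compounds shown here, hydrogen in place of ethoxy on the aromatic carbon ortho to a hydroxy group gives the first step that lies beyond the scatter (a 2.5-fold lower number from compound 2 to compound 3 (0.40 log units; beyond the scatter)), though it is modest. The 4-hydroxyphenyl group of compound 3 and the 3,4-dimethoxyphenyl group of compound 1 cannot be ranked (a 1.5-fold lower number from compound 1 to compound 3 (0.16 log units; within the scatter)), so only compound 2 and compound 3 separate, and compound 1 sits within the scatter of both. No measurement at hand accounts for the step.

From the compounds shown here alone, how a propoxy chain, an amine or a carboxylic acid on this aromatic carbon would read remains open. Also open, going by these compounds, is whether the step from ethoxy to hydrogen holds when the rest of the shared core differs, since it rests on this single pair.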